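This account rests on a few compounds, and the source may have more. Where it says the series, first, only, none or still open, it means among the compounds named here.

Working notes on the series. Compound 1 `CC1CCCC(OCCCCCCN2C[C@H](O)[C@@H](O)[C@H](O)[C@H]2CO)C1C`, compound 2 `OC[C@@H]1[C@@H](O)[C@H](O)[C@@H](O)CN1CCCCCCOc1ccccc1C(F)(F)F` and compound 3 `CCC1CCC(OCCCCCCN2C[C@H](O)[C@@H](O)[C@H](O)[C@H]2CO)CC1` share one core and differ only in the group on an oxygen on a saturated carbon. In an ADME assay on MDBK cells (Bos taurus) for cytotoxicity, read by MTT assay (on this read-out lower numbers stand for higher toxicity in this test and higher numbers for lower toxicity in this test), compound 1 gives > 500000 nM, which is a limit of the assay and not a number. In this assay compound 2 gives > 500000 nM, again a limit. In this assay compound 3 gives > 500000 nM, also a limit. For the measured compounds named here, the one pair differing in a single place is a step that the two limits leave unreadable from compound 1 to compound 3. Compound 3 therefore stands with the others, at the limit of > 500000 nM in this assay, at which 3 of the 3 values shown sit.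

Compound 4 `COc1ccccc1OCCCCCCN1C[C@H](O)[C@@H](O)[C@H](O)[C@H]1CO` is not yet measured in this assay. It differs from compound 3 in one place: 2-methoxyphenyl in place of 4-ethylcyclohexyl on an oxygen on a saturated carbon. Going by the values given here, no measured step has a readable size, and compound 2 also gives only a limit, so no direction beyond the scatter can be expected from the change. The step of a number no higher from compound 3 to compound 4 (the limit leaves the size open) is estimated to be flat, with a limit the most likely outcome again. For compound 4 the estimate in this assay is 500000 nM, expected between 150000 nM and 1000000 nM.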

Compound 4, half-maximal cytotoxic concentration: > 500000 nM
Compound 4: only a limit was reported; the forecaster's own chance of this, stated with the estimate: 85%; the middle value lies on the limit itself.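

No step to compound 4 from compound 1, compound 2 or compound 3 can be read in this assay, as each end of these steps is a limit and not a number: the limit of > 500000 nM in this assay, at which 4 of the 4 values shown sit.

The compounds shown leave open how far any of these groups on an oxygen on a saturated carbon shifts the read-out in this assay.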